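Removing the Chloro Group from Compound 3

A few compounds are considered here, and "the series" means these few. Any claim that something is new, unique, unknown or untested is made for them only; others in the source may bear on it.

Compound 1 `Cc1ccc(N2CCN/C2=N\N)cc1` gives 12%.
Compound 2 `N=c1c(=O)[nH]nc2n1CCN2c1cccc(Cl)c1` gives 3%.
Compound 3 `N=c1c(=O)[nH]nc2n1CCN2c1ccccc1Cl` gives 0%.

Three compounds were tested in a functional assay on T47D cells (Homo sapiens) for cytotoxicity, with a stated time of 72 h, tested at 10 ug/mL; a lower number here means a weaker effect, a higher number a stronger effect of the compound at the concentration tested. Compound 3 stands lowest of the three numbers. Its nearest neighbour is compound 2, whose number differs from it by a gap that stays within the scatter of repeated measurements, so the two cannot be told apart. The furthest is compound 1, which differs from compound 3 by a gap beyond the scatter. Compound 2 and compound 3 share a core and differ only in where the chloro group sits on the phenyl ring; compound 1 has a different core, so no single-point comparison links it to the other two.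

Compound 4 `N=c1c(=O)[nH]nc2n1CCN2c1ccccc1` is the next compound. Compared with compound 3, the change is hydrogen in place of chloro on an aromatic carbon. For the measured compounds named here, no measured pair shows this change, so there is no step to lean on. With compound 2 and compound 3 sitting close together at the bottom of the range, the expectation is that the change will produce no step beyond the scatter, which is what the expected step of a number 3 percentage points higher from compound 3 to compound 4 (within the scatter) in this assay means. Compound 4 is therefore estimated at 3%, in a range from 0% to 12%.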

Compound 4, a percentage reported as inhibition, at one concentration (the size of the read-out at that concentration, not a potency): 0%
Compound 4: the middle estimate sits 3 percentage points above what was measured; the range from low to high includes it.
By their numbers in this assay, from the lowest: compounds 3, 4, 2 and 1 (each within the scatter of the next, the first and the last beyond it).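

In this assay, hydrogen in place of chloro on an aromatic carbon, ortho to a large group, gives no change at the digits printed from compound 3 to compound 4 (within the scatter) and the same exchange starting from the other chloro placement gives a number 3 percentage points lower from compound 2 to compound 4 (within the scatter), so the shared core now has a reading with no chloro group at all. For the compounds shown here, the earlier compounds showed only that moving the chloro group around the ring left the number within the scatter, whereas these two steps show that removing it does so as well, and at this level of effect the chloro group leaves no detectable mark on the read-out at either placement. Nothing measured here speaks to why the change leaves the number where it is.

From the compounds shown here alone, whether another group at this place, such as an amine, a methoxy group or a carboxylic acid, would lift the number clear of the scatter remains open. Going by these compounds, compounds 2, 3 and 4 all sit at the bottom of the range, so it also remains open whether the shared core can carry a larger effect in this assay at all.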